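Bromo to methoxy on compound 3

This account rests on a few compounds, and the source may have more. Where it says the series, first, only, none or still open, it means among the compounds named here.

In an ADME assay on Vero cells (Chlorocebus sabaeus) for cytotoxicity, read by CellTiter-Glo, with a stated time of 72 h (on this read-out higher numbers stand for lower toxicity in this test and lower numbers for higher toxicity in this test), compound 1 (`[O-][n+]1nc(NC2CCC2)[n+]([O-])c2ccc(Br)cc21`) gives 3.8 ug/mL, compound 2 (`[O-][n+]1nc(NC2CCCC2)[n+]([O-])c2ccc(Br)cc21`) gives 18 ug/mL and compound 3 (`[O-][n+]1nc(N[C@@H]2C[C@H]3CC[C@@H]2C3)[n+]([O-])c2ccc(Br)cc21`) gives 0.8 ug/mL, the lowest of the three numbers. Compound 4 (`COc1ccc2c(c1)[n+]([O-])nc(N[C@@H]1C[C@H]3CC[C@@H]1C3)[n+]2[O-]`) differs from compound 3 by methoxy in place of bromo on an aromatic carbon. Among the measured compounds shown here, the measured steps, a 4.7-fold higher number from compound 1 to compound 2 (0.68 log units; beyond the scatter), a 4.8-fold lower number from compound 1 to compound 3 (0.68 log units; beyond the scatter) and a 23-fold lower number from compound 2 to compound 3 (1.35 log units; beyond the scatter), all change the group on nitrogen, so they show only that modest to large steps occur. None tests the bromo. The expected step is therefore small, a 1.8-fold higher number from compound 3 to compound 4 (0.24 log units; within the scatter), not beyond the scatter, though with wide uncertainty. The estimate for compound 4 is 1.4 ug/mL, with an expected range of 0.4 ug/mL to 5 ug/mL.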

Compound 4, half-maximal cytotoxic concentration: > 50 ug/mL
Compound 4 gave a limit, no number; the forecaster's own chance of this, stated with the estimate: 3%; middle value at least 35-fold (1.55 log units) away from the limit.
By their numbers in this assay, from the lowest: compound 3; then compound 1; then compound 2. At a limit, above all of these: compound 4.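

In this assay, among the compounds shown here, methoxy in place of bromo on an aromatic carbon gives an at least 62-fold higher number from compound 3 to compound 4 (1.79 log units; beyond the scatter), so this position, which all the earlier compounds left as bromo, can move the read-out strongly. This step exceeds every step seen among the groups on nitrogen. Compound 4 gives a limit, not a number: the limit of > 50 ug/mL in this assay, at which 1 of the 4 values shown sits.

As far as these compounds go, whether hydrogen, chloro or ethoxy at this position would read like bromo or like methoxy stays open. So does whether the same change carries over to the cyclobutyl and cyclopentyl groups of compound 1 and compound 2.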